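This account rests on a few compounds, and the source may have more. Where it says the series, first, only, none or still open, it means among the compounds named here.

Three compounds share one core and differ only in the group hanging from the benzylic carbon bound to the amine nitrogen. In an ADME assay on MT4 cells (Homo sapiens) for cytotoxicity, read by MTT assay, with a stated time of 5 days (on this read-out lower numbers stand for higher toxicity in this test and higher numbers for lower toxicity in this test), compound 1 `Cc1cc(C#N)cc(C)c1Oc1nc(NC2CCC(NCc3ccc(S(N)(=O)=O)cc3)CC2)nc2ccsc12` gives 3690 nM, compound 2 `Cc1cc(C#N)cc(C)c1Oc1nc(NC2CCC(NCc3ccc(C(N)=O)cc3)CC2)nc2ccsc12` gives 7720 nM, and compound 3 `Cc1cc(C#N)cc(C)c1Oc1nc(NC2CCC(NCc3cccc(C(N)=O)c3)CC2)nc2ccsc12` gives 9210 nM. Compound 3 and compound 2 sit within the scatter of each other, the step being a 1.2-fold higher number from compound 2 to compound 3 (0.08 log units; within the scatter), while compound 1 lies clearly apart: a 2.5-fold higher number from compound 1 to compound 3 (0.40 log units; beyond the scatter) and a 2.1-fold higher number from compound 1 to compound 2 (0.32 log units; beyond the scatter).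

Compound 4 `Cc1cc(C#N)cc(C)c1Oc1nc(NC2CCC(NCc3ccc([N+](=O)[O-])cc3)CC2)nc2ccsc12` is the next step from compound 3: 4-nitrophenyl in place of 3-carbamoylphenyl on a saturated chain carbon bound to an amine nitrogen. Among the compounds with values here, no measured pair carries a nitro group, so the only guide is that every swap so far on this benzyl position moved this assay by a modest amount or not at all. The expectation is therefore a step of a 1.3-fold lower number from compound 3 to compound 4 (0.12 log units; within the scatter), that is, little change beyond the scatter in either direction. Compound 4 is estimated at 7000 nM, with a range from 3000 nM to 16000 nM.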

Compound 4, half-maximal cytotoxic concentration: 54400 nM
Estimate against measurement, compound 4: 7.8-fold (0.89 log units) below; the measured number lies above the stated range.
By their numbers in this assay, from the lowest: compound 1; then compounds 2 and 3 (each within the scatter of the next); then compound 4.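

In this assay this place on the benzyl group proves far more sensitive than the first three compounds suggested, since replacing either amide-bearing ring with 4-nitrophenyl raises the number well beyond the scatter (a 5.9-fold higher number from compound 3 to compound 4 (0.77 log units; beyond the scatter); a 7.0-fold higher number from compound 2 to compound 4 (0.85 log units; beyond the scatter)). The step from the sulfamoyl compound is larger still and counts as large (a 15-fold higher number from compound 1 to compound 4 (1.17 log units; beyond the scatter)), which places compound 4 as the least toxic of the four in this test. Nothing available here gives a reason for this jump.

The compounds shown leave open whether the rise belongs to the nitro group itself or simply to a group with 0 hydrogen-bond donors. A nitrile or an amine on the same ring would help to tell these apart.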